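Swapping the thiadiazole on the sulfur for a thiazoline ring

The compounds below may be only part of what the source reports. "The series", "measured", "known", "first", "only" and "open" are said of these compounds alone.

Measured compounds:
Compound 1 `Cc1ccc2oc(SCC(=O)Nc3ccc(-c4nc(-c5ccccc5)c(-c5ccccc5)n4C)cc3)nc2c1`: 25.6%
Compound 2 `Cn1c(-c2ccc(NC(=O)CSc3nc4ccccc4s3)cc2)nc(-c2ccccc2)c1-c1ccccc1`: 36.8%
Compound 3 `Cc1nnc(SCC(=O)Nc2ccc(-c3nc(-c4ccccc4)c(-c4ccccc4)n3C)cc2)s1`: 73%

All three compounds share the same core and differ only in the ring attached to the sulfur. In a functional assay on HT-29 cells (Homo sapiens) for cytotoxicity, read by MTT assay, with a stated time of 24 h, tested at 6.4 ug/mL (on this read-out higher numbers stand for a stronger effect at the one concentration tested and lower numbers for a weaker effect), compound 3 gives the highest of the three numbers; the nearest is compound 2, which lies a number 36.2 percentage points higher from compound 2 to compound 3 (beyond the scatter), and the furthest is compound 1, which lies a number 47.4 percentage points higher from compound 1 to compound 3 (beyond the scatter). Both of these steps replaced a larger fused ring on the sulfur with the 5-methyl-1,3,4-thiadiazol-2-yl group, and both were large.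

Compound 4 `Cn1c(-c2ccc(NC(=O)CSC3=NCCS3)cc2)nc(-c2ccccc2)c1-c1ccccc1` is not yet measured. Its change from compound 3 is a group of 5 heavy atoms (3 carbon, 1 nitrogen, 1 sulfur; one five-membered non-aromatic ring with 2 hetero atoms) in place of a group of 6 heavy atoms (3 carbon, 2 nitrogen, 1 sulfur; one five-membered aromatic ring with 3 hetero atoms), on a sulfur. The measured steps all arrive at the 5-methyl-1,3,4-thiadiazol-2-yl group rather than leave it, so none maps directly onto this change. Because a number 47.4 percentage points higher from compound 1 to compound 3 (beyond the scatter) and a number 36.2 percentage points higher from compound 2 to compound 3 (beyond the scatter) show that the other two rings on the sulfur gave clearly lower numbers, a step downward from compound 3 to compound 4 is expected, estimated at a number 23 percentage points lower from compound 3 to compound 4 (beyond the scatter). Compound 4 is thus expected to give about 50% in this assay, with a range from 25% to 78%.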

Compound 4, a percentage reported as activity, at one concentration (the size of the read-out at that concentration, not a potency): 31%
Beside the measured number, compound 4's estimate is 19 percentage points above it; measured number inside the range.
By their numbers in this assay, from the lowest: compounds 1, 4 and 2 (each within the scatter of the next, the first and the last beyond it); then compound 3.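

The step of a number 42 percentage points lower from compound 3 to compound 4 (beyond the scatter) shows that a small, unfused ring on this sulfur does not by itself keep the number high in this assay: the five-membered non-aromatic ring loses most of what the 5-methyl-1,3,4-thiadiazol-2-yl group gave. The larger fused groups offer no separation from it, with a number 5.8 percentage points lower from compound 2 to compound 4 (within the scatter) and a number 5.4 percentage points higher from compound 1 to compound 4 (within the scatter), so among these four rings compound 3 alone stands out. No supporting data bear on why this change has such an effect.

The compounds shown leave open which feature of the 5-methyl-1,3,4-thiadiazol-2-yl group matters: its aromatic ring, its second ring nitrogen or its methyl. A 1,3,4-thiadiazol-2-yl ring carrying an amine in place of that methyl would be one way to begin separating these features.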